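The source may report more compounds than this note shows. Statements on the series, on what has been measured and on what is new or still open speak of the compounds shown alone.

Among the measured compounds shown here, compound 1 `CNC(=O)[C@@H]1C[C@H](N2CCc3ccccc3C2)CN1C(=O)c1ccc(CN)c(OC)c1` gives 490 nM in an assay on isolated protein for inhibition of serine protease 1 (Homo sapiens), read by fluorescence (on this read-out higher numbers stand for weaker inhibition and lower numbers for stronger inhibition), which is the higher of the two numbers measured so far. Compound 2 `COc1cc(C(=O)N2C[C@@H](n3cc(C4CC4)nn3)C[C@H]2C(=O)N2CC[C@@H](c3ccccc3)C2)ccc1CN` gives 330 nM in this assay, and the two values sit within the scatter of each other, so the data do not separate them. Compound 3 `CNC(=O)[C@@H]1C[C@H](N2CCc3c(cccc3OCCC3CC3)C2)CN1C(=O)c1ccc(CN)c(OC)c1` has not yet been measured in this assay. It differs from compound 1 in one place: 2-cyclopropylethoxy in place of hydrogen on an aromatic carbon. For the measured compounds named here, no step between two measured compounds shows what such a change does, so the direction has to be guessed rather than read off. The expectation is for compound 3 to come out a little lower than compound 1, a step of a 1.6-fold lower number from compound 1 to compound 3 (0.21 log units; within the scatter), though a result within the scatter would be no surprise. The estimate for compound 3 in this assay is 300 nM, with a likely range from 100 nM to 900 nM.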

Compound 3, half-maximal inhibitory concentration: 2 nM
Compound 3: middle estimate off by 150-fold (2.18 log units), on the high side; the whole stated range lies above it.
By their numbers in this assay, from the lowest: compound 3; then compounds 2 and 1 (each within the scatter of the next).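

Replacing hydrogen with 2-cyclopropylethoxy brings a 250-fold lower number from compound 1 to compound 3 (2.39 log units; beyond the scatter) in this assay. This shows that an aromatic carbon ortho to a fused ring and meta to a fused ring can accept a substituent, and that a single change there can strengthen inhibition far beyond the scatter, which compound 1 and compound 2 could not reveal. Nothing available explains why this one change has so large an effect.

The compounds shown leave open which part of the new group matters: a methoxy group, a plain ethoxy group, a longer chain without the cyclopropyl ring, an amine or a carboxylic acid at this carbon would help separate the roles of the oxygen, the chain and the ring. They also leave open whether 2-cyclopropylethoxy would do as much on another carbon of this aromatic ring.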